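Swapping a methoxy for an acetyl on the outer ring

This account rests on a few compounds, and the source may have more. Where it says the series, first, only, none or still open, it means among the compounds named here.

Two compounds share one core. Compound 1 `Brc1cn2ccnc2c(-c2ccc3ncn(C4CCCCC4)c3c2)n1` carries a bromo group on an aromatic carbon, while compound 2 `COc1ccc(-c2cn3ccnc3c(-c3ccc4ncn(C5CCCCC5)c4c3)n2)cc1` carries a 4-methoxyphenyl group at that position. In a functional assay on UACC-62 cells (Homo sapiens) for inhibition, read by sulforhodamine B assay, with a stated time of 48 h, tested at 10 uM (on this read-out higher numbers stand for more inhibition at the one concentration tested (going by the name of the read-out) and lower numbers for less inhibition), compound 1 gives 19.8% and compound 2 gives 65.2%. The step of a number 45.4 percentage points higher from compound 1 to compound 2 (beyond the scatter) is the only measured one, and it places compound 2 at the top of the two numbers shown. Compound 3 `CC(=O)c1ccc(-c2cn3ccnc3c(-c3ccc4ncn(C5CCCCC5)c4c3)n2)cc1` has not been measured. Its difference from compound 2 is acetyl in place of methoxy on an aromatic carbon. Among the measured compounds shown here, no measured step addresses this kind of exchange: the one available step trades a bromo for a whole 4-methoxyphenyl group, a much larger change than exchanging one substituent for another on that ring. It shows the ring matters, not which group sits on it. The step of a number 7.2 percentage points lower from compound 2 to compound 3 (within the scatter) is therefore expected to stay within the scatter. Compound 3 is estimated at 58% in this assay, within a range from 35% to 80%.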

Compound 3, a percentage reported as inhibition, at one concentration (the size of the read-out at that concentration, not a potency): 18.5%
For compound 3 the middle estimate is 39.5 percentage points above the measured one; the measured number lies below the stated range.
By their numbers in this assay, from the lowest: compounds 3 and 1 (each within the scatter of the next); then compound 2.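

In this assay, a phenyl ring at this position does not bring a high number by itself; the small group on that ring, para to a large group, makes a large difference. Acetyl in place of methoxy gives a number 46.7 percentage points lower from compound 2 to compound 3 (beyond the scatter), and 4-acetylphenyl in place of bromo gives only a number 1.3 percentage points lower from compound 1 to compound 3 (within the scatter), so compound 3 cannot be told apart from compound 1, which lacks the outer ring altogether. No supporting data explain why so small an exchange has so large an effect.

The compounds shown leave open whether the high number of compound 2 is particular to methoxy or would also appear with an amine or a longer chain such as ethoxy at the same place. From the compounds shown here alone, it is also open whether a carboxylic acid there would match methoxy or acetyl.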